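Hydroxymethoxybenzyl for furyl on a second aminoquinoline core

This account rests on a few compounds, and the source may have more. Where it says the series, first, only, none or still open, it means among the compounds named here.

Measured compounds:
compound 1 `COc1cccc(CNCCCNc2ccnc3cc(-c4ccc(C(C)(C)C)cc4)ccc23)c1O`, 690 nM
compound 2 `CC(C)(C)c1ccc(-c2ccc3c(NCCCNCc4ccco4)ccnc3c2)cc1`, 3150 nM
compound 3 `FC(F)(F)c1cc(-c2ccc3c(NCCCNCc4ccco4)ccnc3c2)cc(C(F)(F)F)c1`, 2410 nM

Of the compounds shown here, three have been tested in an ADME assay on HepG2 cells (Homo sapiens) for cytotoxicity, read by luminescence, CellTiter-Glo and ATP content, with a stated time of 72 h; a lower number here means that less compound is needed, a higher number that more compound is needed for the effect. Compound 1 gives 690 nM, compound 2 gives 3150 nM, and compound 3 gives 2410 nM. Compound 2 and compound 1 differ in one place, (2-hydroxy-3-methoxyphenyl in place of furan-2-yl on a saturated chain carbon bound to an amine nitrogen), and this change makes a 4.6-fold lower number from compound 2 to compound 1 (0.66 log units; beyond the scatter) in this assay. Compound 3 and compound 2 differ in their cores, and that difference is not broken down here; their two numbers in this assay lie within the usual scatter of each other, so no order between them can be read from the data. Compound 3 and compound 1, by contrast, are separated by more than the scatter, with compound 1 giving the lower number.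

Compound 4 `COc1cccc(CNCCCNc2ccnc3cc(-c4cc(C(F)(F)F)cc(C(F)(F)F)c4)ccc23)c1O` has not yet been tested. Among the compounds with values here, it differs from compound 3 by 2-hydroxy-3-methoxyphenyl in place of furan-2-yl on a saturated chain carbon bound to an amine nitrogen, which is the same change as the one from compound 2 to compound 1, made on the core of compound 3 instead. Since that change produced a 4.6-fold lower number from compound 2 to compound 1 (0.66 log units; beyond the scatter), the step from compound 3 to compound 4 in this assay is expected to be of similar direction, estimated as a 4.0-fold lower number from compound 3 to compound 4 (0.60 log units; beyond the scatter). This rests on a single precedent, and the two cores are not the same, so the expected range is kept wide. Compound 4 is accordingly estimated at 600 nM in this assay, expected to lie between 250 nM and 1500 nM.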

Compound 4, half-maximal effective concentration: 940 nM
Estimate against measurement, compound 4: 1.6-fold (0.19 log units) below; the measured number falls inside the stated range.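

In this assay, the new pair repeats the change already seen on the core of compound 2: 2-hydroxy-3-methoxyphenyl in place of furan-2-yl on a saturated chain carbon bound to an amine nitrogen gives a 2.6-fold lower number from compound 3 to compound 4 (0.41 log units; beyond the scatter). Set beside the earlier step, the new one points the same way and cannot be told apart from it in size: the same change on two cores in this assay, a 4.6-fold lower number (0.66 log units; beyond the scatter) from compound 2 to compound 1 and a 2.6-fold lower number (0.41 log units; beyond the scatter) from compound 3 to compound 4, 1.8-fold (0.25 log units) apart, within the scatter of two such steps. On these two cores, then, the change carries over in direction and, as far as the scatter allows, in size, but two pairs make no rule for the series, and they neither show nor exclude a smaller dependence on the core that the scatter could hide.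

The compounds shown leave open what a plain benzyl group, or a benzyl group carrying only the hydroxyl or only the methoxy, would give on either core, and so which part of the 2-hydroxy-3-methoxybenzyl group goes with the step. Also open, from the compounds shown here alone, are the effect of a longer chain linking the two amine nitrogens and whether the step would hold on a third core, such as one whose aryl group carries a nitrile or a carboxylic acid.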